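Dimethoxyphenyl replaces dichlorophenyl on the enone carbonyl

This account rests on a few compounds, and the source may have more. Where it says the series, first, only, none or still open, it means among the compounds named here.

Compound 1 `COc1cc(-c2cc(/C=C/C(=O)c3ccc(N)cc3)[nH]n2)cc(OC)c1OC` gives 3210 nM in a functional assay on MDA-MB-435 cells (Homo sapiens) for inhibition, read by sulforhodamine B assay, with a stated time of 48 h; on this read-out higher numbers stand for weaker inhibition of growth and lower numbers for stronger inhibition of growth. Compound 2 `COc1cc(-c2cc(/C=C/C(=O)c3ccc(Cl)c(Cl)c3)[nH]n2)cc(OC)c1OC` reaches only the limit of > 100000 nM in this assay, a limit and not a number, as the limit of > 100000 nM in this assay, at which 1 of the 2 values shown sits, records. Among the compounds with values here, the step of an at least 31-fold higher number from compound 1 to compound 2 (1.49 log units; beyond the scatter) is the one measured step that touches this position. Compound 3 `COc1ccc(C(=O)/C=C/c2cc(-c3cc(OC)c(OC)c(OC)c3)n[nH]2)cc1OC` differs from compound 2 by 3,4-dimethoxyphenyl in place of 3,4-dichlorophenyl on a carbonyl carbon. Since compound 2 stands only at a limit, the size of the step is uncertain. The aminophenyl of compound 1 at 3210 nM suggests a dimethoxyphenyl may regain some inhibition. Compound 3 is therefore expected to show an at least 6.6-fold lower number from compound 2 to compound 3 (0.82 log units; beyond the scatter), with an estimate of 15000 nM (range 3000 nM to 100000 nM).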

Compound 3, concentration for total growth inhibition: 2710 nM
Beside the measured number, compound 3's estimate is 5.5-fold (0.74 log units) above it, outside the stated range (below it).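

On the carbonyl carbon, 3,4-dimethoxyphenyl stands clearly apart from 3,4-dichlorophenyl, with an at least 36-fold lower number from compound 2 to compound 3 (1.56 log units; beyond the scatter). Going by these compounds, the true size of that step stays unknown, as compound 2 gives a limit and not a number: the limit of > 100000 nM in this assay, at which 1 of the 3 values shown sits. Exchanging 4-aminophenyl for 3,4-dimethoxyphenyl makes no difference beyond the scatter, with a 1.2-fold lower number from compound 1 to compound 3 (0.07 log units; within the scatter), so two differently substituted phenyl groups give matching results at this position, and only 3,4-dichlorophenyl departs from them. The compounds shown leave open how an unsubstituted phenyl or a pyridine ring on the carbonyl carbon would compare, and so whether the chlorine atoms alone set compound 2 apart.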